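This account rests on a few compounds, and the source may have more. Where it says the series, first, only, none or still open, it means among the compounds named here.

Going by the values given here, compound 1 `Cc1csc2c(N[C@@H](C)CN3CCN(S(=O)(=O)c4ccc(Cl)c(Cl)c4)CC3)ncnc12` is the one compound here with a measured number. Among the compounds with values here, in a functional assay on RH7777 cells for antagonist activity at lysophosphatidic acid receptor 2 (Homo sapiens), read by calcium flux (a higher number here means a weaker inhibitor, a lower number a stronger inhibitor), compound 1 gives 17 nM, which is the only plain number in the set. Compound 2 `COc1ccccc1N1CCN(CC(C)(C)Nc2nc(C(F)(F)F)nc3ccccc23)CC1` reaches only the limit of this assay, and in this assay compound 2 is recorded as > 30000 nM. That limit is the limit of > 30000 nM in this assay, at which 1 of the 2 values shown sits; it says only that no inhibition strong enough to be measured was found.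

Compound 3 `Cc1cccc(S(=O)(=O)N2CCN(C[C@H](C)Nc3ncnc4c(C)csc34)CC2)c1` keeps the whole of compound 1 except one group: 3-methylphenyl in place of 3,4-dichlorophenyl on a sulfonyl sulfur. Within the data shown here, no measured pair here shows what such an exchange does, so the expectation rests on compound 1 alone. A step of a 3.5-fold higher number from compound 1 to compound 3 (0.55 log units; beyond the scatter) toward somewhat weaker inhibition is expected, of modest size. Compound 3 is therefore estimated at 60 nM, with the likely range running from 15 nM to 300 nM.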

Compound 3, half-maximal inhibitory concentration: 310 nM
Compound 3: middle estimate off by 5.2-fold (0.71 log units), on the low side; the whole stated range lies below it.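

The group on the sulfonyl sulfur clearly matters in this assay: with the rest of the molecule unchanged, 3-methylphenyl in place of 3,4-dichlorophenyl gives an 18-fold higher number from compound 1 to compound 3 (1.26 log units; beyond the scatter) and so a much weaker inhibitor. Both groups are a single six-membered aromatic ring of carbon only, with no hydrogen-bond donors or acceptors and no net charge, so a large step here can arise between groups that these counts do not tell apart. The limit recorded for compound 2 has no bearing on this step, as that compound differs from compound 1 in more than one place, and nothing shown gives a measured reason for the step.

Going by these compounds, it remains open whether the two chlorines or the methyl group account for the step, which a plain phenyl ring or a ring with one chlorine could help to separate. On these data alone, it is equally open how this position would respond to a methoxy group, an amine or a carboxylic acid on the ring.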